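The source may report more compounds than this note shows. Statements on the series, on what has been measured and on what is new or still open speak of the compounds shown alone.

In an ADME assay on HOS cells (Homo sapiens) for cytotoxicity (a lower number here means that less compound is tolerated, a higher number that more compound is tolerated), compound 1 `CN(C)CCCc1cccc2nc(CN(C)C3CCCc4cccnc43)[nH]c12` gives 7500 nM, compound 2 `CN(Cc1nc2cccc(CCCN3CCCCC3)c2[nH]1)C1CCCc2cccnc21` gives 8700 nM and compound 3 `CN1CCN(c2cccc3nc(CN(C)C4CCCc5cccnc54)[nH]c23)CC1` gives 14000 nM. Compound 3 therefore holds no clear place of its own, since it lies within the scatter of both other compounds. Compound 4 `CN1CCN(c2cccc3nc(CN(C)[C@@H]4CCCc5cccnc54)[nH]c23)CC1` differs from compound 3 by the two compounds have the same atoms and bonds; at least one stereo element is drawn with a configuration in one of them and without one in the other: 1 of 1 stereo elements differ; a stereocentre at a saturated ring carbon is drawn without a configuration in compound 3 and R in compound 4: a stereocentre at a saturated ring carbon is drawn without a configuration in compound 3 and R in compound 4. Among the measured compounds shown here, no measured pair isolates such a difference, so the evidence is only indirect. Swapping the group on the chain gives a 1.2-fold higher number from compound 1 to compound 2 (0.06 log units; within the scatter), while replacing the whole side group gives a 1.9-fold higher number from compound 1 to compound 3 (0.27 log units; within the scatter) and a 1.6-fold higher number from compound 2 to compound 3 (0.21 log units; within the scatter). All three steps stay within the scatter, so these numbers give no reason to expect a real shift in this assay. The expected result is no change at the digits printed from compound 3 to compound 4 (within the scatter), meaning no step beyond the scatter and no favoured direction. The estimate for compound 4 is 14000 nM, with the measurement expected between 6500 nM and 30000 nM.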

Compound 4, half-maximal cytotoxic concentration: 12300 nM
For compound 4 the middle estimate is 1.1-fold (0.06 log units) above the measured one; low and high end bracket the measured number.
By their numbers in this assay, from the lowest: compounds 1, 2, 4 and 3 (each within the scatter of the next).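

In this assay, among the compounds shown here, the step shows a 1.1-fold lower number from compound 3 to compound 4 (0.06 log units; within the scatter) and so gives the first direct look at this stereocentre at a saturated ring carbon, which compounds 1, 2 and 3 all carry without a drawn configuration. The two compounds can be compared cleanly, as a single feature separates them: the fact that one of compounds 3 and 4 is drawn with a defined configuration and the other without, at the place where they differ. Drawing the R configuration therefore goes with no readable difference in tolerated concentration here, and the 4-methylpiperazin-1-yl side group stays the same throughout this comparison.

The compounds shown leave open how the S configuration at this carbon would read, and whether the R configuration would read the same with the 3-(dimethylamino)propyl or 3-(piperidin-1-yl)propyl side groups. They also leave open whether a different side group on the shared core, such as morpholin-4-yl, would give a step beyond the scatter.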